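Tail Swap on a Shared Core: Estimating Compound 3

This account rests on a few compounds, and the source may have more. Where it says the series, first, only, none or still open, it means among the compounds named here.

Measured compounds in a functional assay on MCF7 cells (Homo sapiens) for antiproliferative activity, read by MTT assay, with a stated time of 72 h; on this read-out lower numbers stand for stronger inhibition and higher numbers for weaker inhibition:
Compound 1 `COc1cc2c(Nc3ccc(C#N)cc3)ncnc2cc1OCCCN1CCc2ccccc2C1` gives > 100000 nM, which is a limit of the assay and not a number.
Compound 2 `COc1cc2c(Nc3ccc(C#N)cc3)ncnc2cc1OCCCN1CCC(N(C)C)CC1` gives 31000 nM.

Going by the values given here, compound 2 holds the only numerical value shown; the other entry is a limit. Among the compounds with values here, the one measured step, an at least 3.2-fold lower number from compound 1 to compound 2 (0.50 log units; beyond the scatter), changes the group on the same chain carbon, and its size is bounded by the limit of > 100000 nM in this assay, at which 1 of the 2 values shown sits. Compound 3 `COc1cc2c(Nc3ccc(C#N)cc3)ncnc2cc1OCCCN1CCN(c2ccncc2)CC1` carries the change (4-(pyridin-4-yl)piperazin-1-yl in place of 4-(dimethylamino)piperidin-1-yl on a saturated chain carbon, three bonds along the chain from an oxygen on an aromatic ring). Within the data shown here, that step also swaps one nitrogen-bearing tail for another at the same place, so the measured step is the only guide, and it shows that such a swap can shift the number at least modestly. Compound 3 is expected to land near compound 2, with a step of a 1.0-fold lower number from compound 2 to compound 3 (0.01 log units; within the scatter) that may stay within the scatter. The estimate for compound 3 in this assay is 30000 nM, ranging from 8000 nM to 100000 nM.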

Compound 3, half-maximal inhibitory concentration: 22900 nM
Compound 3: middle estimate off by 1.3-fold (0.12 log units), on the high side; the measured number falls inside the stated range.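

In this assay, putting 4-(pyridin-4-yl)piperazin-1-yl in place of 4-(dimethylamino)piperidin-1-yl gives a 1.4-fold lower number from compound 2 to compound 3 (0.13 log units; within the scatter), so these two tails read alike at this place, even though the entering one brings a six-membered aromatic ring. Set against 1,2,3,4-tetrahydroisoquinolin-2-yl, the same tail gives an at least 4.3-fold lower number from compound 1 to compound 3 (0.64 log units; beyond the scatter), so a second tail now stands apart from that group, as 4-(dimethylamino)piperidin-1-yl already did. Compound 1 holds a limit and not a number, so the true size of this step stays unknown: the limit of > 100000 nM in this assay, at which 1 of the 3 values shown sits.

The compounds shown leave open whether a morpholine ring or a carboxylic acid on the same chain carbon would read like these tails. They also leave open whether a longer chain carrying the same tails would shift the number.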